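Adding a hydroxy to the phenyl of compound 2

The source may report more compounds than this note shows. Statements on the series, on what has been measured and on what is new or still open speak of the compounds shown alone.

Of the compounds shown here, three sharing one core have been measured in an assay on isolated protein for binding affinity to histone acetyltransferase KAT2B (Homo sapiens), read by fluorescence, tested at 10 uM; on this read-out lower numbers stand for weaker stabilisation of the target and higher numbers for stronger stabilisation of the target against heat. Compound 2 `CN1C[C@H](Nc2nc3cc[nH]c3c(=O)n2C)C[C@H](c2ccccc2)C1` gives 6.3 degrees C, the highest of the three numbers. Compound 3 `C=CCn1c(N[C@@H]2C[C@H](c3ccccc3)CN(C)C2)nc2cc[nH]c2c1=O` gives 2.2 degrees C, and compound 1 `C=CCCn1c(N[C@@H]2C[C@H](c3ccccc3)CN(C)C2)nc2cc[nH]c2c1=O` gives 1.5 degrees C. The step of a number 4.1 degrees C lower from compound 2 to compound 3 (beyond the scatter) and the step of a number 4.8 degrees C higher from compound 1 to compound 2 (beyond the scatter) both lie beyond the scatter, so compound 2 stands clearly apart from the other two, while the step of a number 0.70 degrees C higher from compound 1 to compound 3 (within the scatter) stays within it.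

Compound 4 `CN1C[C@H](Nc2nc3cc[nH]c3c(=O)n2C)C[C@H](c2ccc(O)cc2)C1` departs from compound 2 at a different spot. The change is hydroxy in place of hydrogen on an aromatic carbon: a phenyl becomes a 4-hydroxyphenyl on a six-membered aromatic ring of carbon only. Going by the values given here, none of the measured steps touches this ring; all three concern the group on the saturated chain carbon bound to the aromatic nitrogen. Among the compounds with values here, there is therefore no measured step that bears on the change from compound 2 to compound 4, and nothing in the data to argue for a shift in either direction beyond the scatter.

On that basis compound 4 is expected to give about 6 degrees C in this assay, within a range from 3.5 degrees C to 8.5 degrees C, which means an estimated step of a number 0.30 degrees C lower from compound 2 to compound 4 (within the scatter) that may well fall inside the usual scatter.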

Compound 4, shift of the target's melting temperature: 8.4 degrees C
For compound 4 the middle estimate is 2.4 degrees C below the measured one, within the range that was stated.
By their numbers in this assay, from the lowest: compounds 1 and 3 (each within the scatter of the next); then compound 2; then compound 4.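

The 4-hydroxyphenyl of compound 4 shows that the phenyl ring is not a silent part of the series in this assay: hydroxy in place of hydrogen on an aromatic carbon, para to a large group, gives a number 2.1 degrees C higher from compound 2 to compound 4 (beyond the scatter). The earlier compounds shown here varied only the group on the saturated chain carbon bound to the aromatic nitrogen, so they could say nothing about this ring, which is now a second place where a single change moves the number beyond the scatter. Here the number rises, unlike the drop of a number 4.1 degrees C lower from compound 2 to compound 3 (beyond the scatter) at the other place, though no accompanying measurement accounts for the rise.

The compounds shown leave open whether this gain is particular to hydroxy, since a methoxy group, an amine or a fluorine at the same place on the ring does not appear among them. On these data alone, it also remains open whether the same hydroxy would raise the number when the shared core carries the longer chains of compound 1 or compound 3.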